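A few compounds are considered here, and "the series" means these few. Any claim that something is new, unique, unknown or untested is made for them only; others in the source may bear on it.

Measured so far:
compound 1 `N#C[Se]c1ccc(NC(=O)OCc2ccc([N+](=O)[O-])cc2)cc1` — 32800 nM
compound 2 `CC(C)COC(=O)Nc1ccc([Se][Se]c2ccc(NC(=O)OCC(C)C)cc2)cc1` — 42700 nM
compound 3 `N#C[Se]c1ccc(NC(=O)OCc2ccccc2)cc1` — 34400 nM

For the measured compounds named here, all three numbers in an ADME assay on BEAS-2B cells (Homo sapiens) for cytotoxicity, read by MTT assay, with a stated time of 72 h (on this read-out higher numbers stand for weaker inhibition of growth and lower numbers for stronger inhibition of growth), lie within the usual scatter of one another, so compound 3 is neither set apart from compound 1 nor from compound 2; the one computed step, a 1.0-fold higher number from compound 1 to compound 3 (0.02 log units; within the scatter), is itself within the scatter.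

Compound 4 `CC(C)COC(=O)Nc1ccc([Se]C#N)cc1` is to be measured in this assay. Its change against compound 3 is isopropyl in place of phenyl on a saturated chain carbon bound to an oxygen next to a carbonyl group. Going by the values given here, no measured step touches this part of the molecule: a 1.0-fold higher number from compound 1 to compound 3 (0.02 log units; within the scatter) concerns a substituent on the aromatic ring and gives no information on the ester side of the carbamate. Among the compounds with values here, compound 2 shares that ester side with compound 4 but differs elsewhere, and no single-point step connects it to any other compound; compound 2 simply gives 42700 nM, in the same band as the rest. With nothing pointing either way, the expected step of a 1.0-fold higher number from compound 3 to compound 4 (0.01 log units; within the scatter) from compound 3 to compound 4 is none beyond the scatter. Compound 4 is therefore estimated at 35000 nM, with a range from 17000 nM to 70000 nM.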

Compound 4, concentration for total growth inhibition: 49500 nM
The estimate for compound 4 lay 1.4-fold (0.15 log units) below the measured number; the range from low to high includes it.
By their numbers in this assay, from the lowest: compounds 1, 3, 2 and 4 (each within the scatter of the next).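

In this assay, the first change read at this position gives a 1.4-fold higher number from compound 3 to compound 4 (0.16 log units; within the scatter), so the step stays within the scatter. On the saturated chain carbon bound to an oxygen next to a carbonyl group, phenyl with its six-membered aromatic ring gives way to isopropyl, which has no ring, without setting the compound apart; the earlier step concerned only a substituent on the aromatic ring. No supporting measurement bears on this result.

Still open, from the compounds shown here alone, is whether an amine, a carboxylic acid or a longer chain at this place would give a step beyond the scatter. For the compounds shown here, the single pair also cannot show whether the same replacement would stay within the scatter on a core other than that of compound 3.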